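This account rests on a few compounds, and the source may have more. Where it says the series, first, only, none or still open, it means among the compounds named here.

Compound 1, `Cc1ccc(S(=O)(=O)Cc2ccccc2)cc1C#Cc1cc(Cl)ccc1OCC(=O)O`, was tested in an assay on CHO cells for displacement of a labelled ligand from prostaglandin D2 receptor 2 (Homo sapiens), read by scintillation counting (a lower number here means a stronger inhibitor, a higher number a weaker inhibitor), where compound 1 gives 5 nM. Two related compounds share its core. Compound 2, `C[S+]([O-])c1cccc(C#Cc2cc(Cl)ccc2OCC(=O)O)c1`, gives 3.2 nM in this assay, a number that sits within the usual scatter of the number for compound 1, so the two cannot be told apart. Compound 3, `O=C(O)COc1ccc(Cl)cc1C#Cc1cncc(S(=O)(=O)N2CCOCC2)c1`, gives 41 nM, a weaker result that lies beyond the scatter. Among the three numbers, compound 1 therefore holds the second highest, close to compound 2 and well apart from compound 3.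

Compound 4, `CCS(=O)(=O)c1ccc(C)c(C#Cc2cc(Cl)ccc2OCC(=O)O)c1`, has not yet been measured. It differs from compound 1 in one place: methyl in place of phenyl on a saturated chain carbon bound to a sulfonyl sulfur. Cut one bond further out, the change reads benzylsulfonyl to ethylsulfonyl. Going by the values given here, no measured pair shows this exact change, so its effect can only be guessed. Compound 2 carries a methylsulfinyl group in place of the whole benzylsulfonyl and still gives 3.2 nM, which suggests that a smaller group on the sulfur does not cost much. The step from compound 1 to compound 4 in this assay is therefore expected to be small, probably no larger than the scatter and with no clear direction, as no change at the digits printed from compound 1 to compound 4 (within the scatter) expresses. On that basis compound 4 is estimated at 5 nM, with a range from 1.5 nM to 16 nM.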

Compound 4, inhibition constant: 8.6 nM
Compound 4: middle estimate off by 1.7-fold (0.24 log units), on the low side; low and high end bracket the measured number.
By their numbers in this assay, from the lowest: compounds 2, 1 and 4 (each within the scatter of the next, the first and the last beyond it); then compound 3.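

Putting methyl in place of phenyl on the saturated chain carbon bound to the sulfonyl sulfur gives a 1.7-fold higher number from compound 1 to compound 4 (0.24 log units; within the scatter), the first step among these compounds that can be read at a single place. In this assay, then, this place accepts the swap of a group of 6 heavy atoms with a six-membered aromatic ring for a single carbon, and compound 1 and compound 4 cannot be told apart, so the phenyl ring is not needed to hold the number in this range. The data shown give no reason for this result.

The compounds shown leave open whether other groups at this place would behave the same way, such as a longer chain like butyl, a cyclohexyl ring, or a chain ending in an amine or a carboxylic acid, since methyl and phenyl are the only two groups compared here. This single pair also cannot say whether the same change would give so small a step on a different core, for example one lacking the methyl group on the ring that carries the sulfonyl.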